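Notes on the step from compound 3 to compound 4

This account rests on a few compounds, and the source may have more. Where it says the series, first, only, none or still open, it means among the compounds named here.

Of the compounds shown here, three of the shared core have been measured in an assay on isolated protein for inhibition of NUAK family SNF1-like kinase 2 (Homo sapiens), read by ADP-Glo, with a stated time of 60 min, tested at 10 uM, in the presence of a further agent that is not named here; a lower number here means less inhibition, a higher number more inhibition at the concentration tested (going by the name of the read-out). Compound 1 `CCC(=O)Nc1cccc(Oc2nc(Nc3ccc(N(C)C)cc3OC)ncc2Cl)c1` gives 15%. Compound 2 `CCC(=O)Nc1cccc(Oc2nc(Nc3ccc(N4CCN(C)CC4)cc3)ncc2Cl)c1` gives 82.6%. Compound 3 `CCC(=O)Nc1cccc(Oc2nc(Nc3ccc(N4CCCC4)cc3OC)ncc2Cl)c1` gives "not active" (no number reported), with no number, so it cannot be placed against the other two by value; it can only be said to sit at the weak end together with compound 1, while compound 2 stands clearly higher.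

Compound 4 `CCCN(CCC)c1ccc(Nc2ncc(Cl)c(Oc3cccc(NC(=O)CC)c3)n2)c(OC)c1` has not been measured. It differs from compound 3 in one place: dipropylamino in place of pyrrolidin-1-yl on an aromatic carbon. Among the compounds with values here, no step between measured compounds covers this change, so its size is not known from the series. The expectation is a step of no more than the usual scatter, or none at all, with compound 4 staying at the weak end of the series. Compound 4 is expected to give about 10% in this assay, within 0% to 30%. This low expectation rests on compound 1, which gives 15% in this assay, and on compound 3, which gives "not active" (no number reported).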

Compound 4, a percentage reported as inhibition, at one concentration (the size of the read-out at that concentration, not a potency): "not active" (no number reported)
No number was reported for compound 4; there is nothing to compare the estimate with.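

In this assay compound 3 gives "not active" (no number reported) and compound 4 gives "not active" (no number reported), so no step can be read between them. From the compounds shown here alone, whether dipropylamino and pyrrolidin-1-yl differ at all in this assay stays open. No measurement shown here bears on this result.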